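The source may report more compounds than this note shows. Statements on the series, on what has been measured and on what is new or still open speak of the compounds shown alone.

Compound 1 `CN(C)C1(Cc2ccccc2)CCN(c2cc(C(F)(F)F)ccc2CNC(=O)Nc2ccc(NS(C)(=O)=O)c(F)c2)CC1` gives 1160 nM in an assay on CHO cells for displacement of a labelled ligand from transient receptor potential cation channel subfamily V member 1 (Homo sapiens), read by scintillation counting, with a stated time of 60 min (a lower number here means a stronger inhibitor, a higher number a weaker inhibitor), the highest number among the three measured compounds; compound 2 `CN(C)C1(Cc2ccccc2)CCN(c2cc(C(F)(F)F)ccc2CNC(=O)Nc2cccc3ccc(O)cc23)CC1` gives 0.46 nM and compound 3 `CN(C)C1(Cc2ccccc2)CCN(c2cc(C(F)(F)F)ccc2CNC(=O)Nc2ccc3c(c2)OCC3)CC1` gives 41.4 nM. Compound 4 `CN(C)C1(Cc2ccccc2)CCN(c2cc(C(F)(F)F)ccc2CNC(=O)Nc2cccc3[nH]c(=O)ccc23)CC1` keeps the shared core and carries a group of 11 heavy atoms (9 carbon, 1 nitrogen, 1 oxygen; one six-membered aromatic ring of carbon only, one six-membered aromatic ring with 1 hetero atom) in place of a group of 12 heavy atoms (7 carbon, 1 nitrogen, 2 oxygen, 1 fluorine, 1 sulfur; one six-membered aromatic ring of carbon only), on an amide-type nitrogen. Within the data shown here, two measured steps bear on this exchange of the aryl group on the amide-type nitrogen for a fused bicyclic group: a 2500-fold lower number from compound 1 to compound 2 (3.40 log units; beyond the scatter) and a 28-fold lower number from compound 1 to compound 3 (1.45 log units; beyond the scatter), both large and in the same direction. A large fall in this assay is therefore expected for compound 4, closer in size to that seen with compound 2 because of the step of a 2500-fold lower number from compound 1 to compound 2 (3.40 log units; beyond the scatter), giving an estimated 580-fold lower number from compound 1 to compound 4 (2.76 log units; beyond the scatter). Compound 4 is expected to give 2 nM, with a range of 0.3 nM to 15 nM.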

Compound 4, inhibition constant: 1.67 nM
Beside the measured number, compound 4's estimate is 1.2-fold (0.08 log units) above it; low and high end bracket the measured number.
By their numbers in this assay, from the lowest: compound 2; then compound 4; then compound 3; then compound 1.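

In this assay, the gain over 3-fluoro-4-(methanesulfonamido)phenyl on the amide-type nitrogen also holds for a fused group whose second six-membered aromatic ring carries a hetero atom (a 690-fold lower number from compound 1 to compound 4 (2.84 log units; beyond the scatter)). The fused groups are not interchangeable: one step is large (a 25-fold lower number from compound 3 to compound 4 (1.39 log units; beyond the scatter)), while the other is modest but beyond the scatter (a 3.6-fold higher number from compound 2 to compound 4 (0.56 log units; beyond the scatter)). Nothing available here accounts for these differences.

Still open, on these data alone, is how this assay would respond to a methyl group on the ring nitrogen of compound 4. As far as these compounds go, the effect of an amine or a carboxylic acid on the fused group is also open.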